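The source may report more compounds than this note shows. Statements on the series, on what has been measured and on what is new or still open speak of the compounds shown alone.

Compound 1 `c1ccc(COc2ccc(OCCOCCNc3cc[nH]c3)cc2)cc1` carries a pyrrole amine on its ether chain. In a functional assay on SK-OV-3 cells (Homo sapiens) for inhibition, read by CCK-8 assay, with a stated time of 70 h (a lower number here means a stronger inhibitor, a higher number a weaker inhibitor), compound 1 gives 11300 nM. Compound 2 `CC(C)(C)OC(=O)n1ccc(NCCOCCOc2ccc(OCc3ccccc3)cc2)c1` gives 13000 nM, and the step of a 1.2-fold higher number from compound 1 to compound 2 (0.06 log units; within the scatter) stays within the scatter. For the measured compounds named here, compound 3 `COC(=O)c1cccc(COc2ccc(OCCOCCNC3CCCC3)cc2)c1`, which has a cyclopentyl amine and a methyl ester on the benzyl group, gives 45500 nM, well beyond the scatter from compound 1, but it differs in two places, so no single step bears on the change here. Compound 4 `c1ccc(COc2ccc(OCCOCCNC3CCCCCC3)cc2)cc1` differs from compound 1 only as cycloheptyl in place of 1H-pyrrol-3-yl on an amine nitrogen. Going by the values given here, with no direct precedent, the cyclopentyl case of compound 3 is the closest hint and points toward a weaker result. Compound 4 is therefore expected to show a 2.7-fold higher number from compound 1 to compound 4 (0.42 log units; beyond the scatter), giving an estimated 30000 nM, within 10000 nM and 90000 nM.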

Compound 4, half-maximal inhibitory concentration: 7460 nM
Compound 4: the middle estimate sits 4.0-fold (0.60 log units) above what was measured; measured number below the stated range.
By their numbers in this assay, from the lowest: compounds 4, 1 and 2 (each within the scatter of the next); then compound 3.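

On the amine nitrogen, cycloheptyl in place of 1H-pyrrol-3-yl gives a 1.5-fold lower number from compound 1 to compound 4 (0.18 log units; within the scatter) in this assay. This position therefore accepts a seven-membered non-aromatic ring of carbon only, without a hydrogen-bond donor, and the number stays within the scatter of that for the five-membered aromatic ring. Nothing measured here explains this result. The compounds shown leave open whether an open hexyl chain or a piperidinyl ring on this nitrogen would give a similar number. Compound 3 cannot settle the effect of ring size, as it differs from compound 1 in two places.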